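Phenyl group change on the oxan-4-yl compound

The source may report more compounds than this note shows. Statements on the series, on what has been measured and on what is new or still open speak of the compounds shown alone.

In an ADME assay (liver) for metabolic stability, with Liver microsome (Homo sapiens) as the target, read by LC-MS, using microsomes, with a stated time of 30 min, tested at 4 uM (on this read-out higher numbers stand for a more stable compound and lower numbers for a less stable compound), compound 1 (`Cc1nc(N2CCN(C)CC2)c2nc(-c3ccccc3Cl)n(CCO)c2n1`) gives 13%, compound 2 (`Cc1nc(N2CCN(C)CC2)c2nc(-c3ccccc3Cl)n(C3CC3)c2n1`) gives 31% and compound 3 (`Cc1nc(N2CCN(C)CC2)c2nc(-c3cccc(Cl)c3)n(C3CCOCC3)c2n1`) gives 25%. Compound 3 lies within the usual scatter of compound 2 and stands above compound 1 by more than the scatter.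

Compound 4 (`Cc1nc(N2CCN(C)CC2)c2nc(-c3ccccc3C)n(C3CCOCC3)c2n1`) follows from compound 3 by one change: 2-methylphenyl in place of 3-chlorophenyl on an aromatic carbon.

For the measured compounds named here, the only measured step confined to one place is a number 18 percentage points higher from compound 1 to compound 2 (beyond the scatter). That step exchanges 2-hydroxyethyl for cyclopropyl on an aromatic nitrogen, at a different place, and offers no direct measure for this change. Going by the values given here, no measured pair isolates a change of the phenyl group, so the direction remains open and the range stays wide.

No step beyond the scatter is expected in this assay. The expected change is a number 2 percentage points lower from compound 3 to compound 4 (within the scatter). The estimate is anchored on compound 3 at 25%. For compound 4 the estimated value is 23%, with an expected range of 11% to 38%.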

Compound 4, percent of the compound remaining: 18%
Compound 4: middle estimate off by 5 percentage points, on the high side, and the stated range covers the measured number.
By their numbers in this assay, from the lowest: compounds 1, 4, 3 and 2 (each within the scatter of the next, the first and the last beyond it).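

This position now has a measured step of its own: in this assay, putting 2-methylphenyl in place of 3-chlorophenyl gives a number 7 percentage points lower from compound 3 to compound 4 (within the scatter) on the oxan-4-yl compound. The exchange keeps the count of heavy atoms and leaves hydrogen-bond donors and acceptors unchanged, and its step stays inside the usual scatter, whereas the step on the aromatic nitrogen, a number 18 percentage points higher from compound 1 to compound 2 (beyond the scatter), lies beyond it. No measured property bears on this result, so the step stands without any explanation.

For the compounds shown here, the single step does not separate the exchange of chlorine for methyl from the different place of the substituent on the phenyl group. On these data alone, how a phenyl group carrying a nitrile or a carboxylic acid would read at this carbon stays open, as does a pyridine ring in place of the phenyl group.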